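The source may hold more compounds than are shown below. What is called first, only, known or untested is meant among the compounds shown, and "the series" means these compounds.

Measured compounds:
compound 1, `COc1cccc(CNCCCNc2ccnc3cc(Cc4ccccc4)ccc23)c1O`, 4200 nM
compound 2, `c1coc(CNCCCNc2ccnc3cc(CC4CCCCC4)ccc23)c1`, 4200 nM

Of the compounds shown here, two have been measured in a physicochemical assay for solubility, with a stated time of 18 h, at pH 7.4; a lower number here means a less soluble compound, a higher number a more soluble compound. Compound 1 `COc1cccc(CNCCCNc2ccnc3cc(Cc4ccccc4)ccc23)c1O` gives 4200 nM. Compound 2 `c1coc(CNCCCNc2ccnc3cc(CC4CCCCC4)ccc23)c1` gives 4200 nM. On these numbers compound 1 stands level with compound 2 at the digits shown; the two values lie within the usual scatter of this assay, so nothing separates them. For the measured compounds named here, no pair of measured compounds differs in only one place, so no step between measured compounds is available to set a scale.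

Compound 3 `COc1cccc(CNCCCNc2ccnc3cc(-c4cccc5ccccc45)ccc23)c1O` has not yet been measured in this assay. It differs from compound 1 in one place: naphthalen-1-yl in place of benzyl on an aromatic carbon. Benzyl, with one six-membered aromatic ring of carbon only, leaves; naphthalen-1-yl, with two six-membered aromatic rings of carbon only, enters, on an aromatic carbon of the shared core. Going by the values given here, the measured pair gives no step that shows how this assay answers such a change. The expectation is a step downward, beyond the scatter, with the step from compound 1 to compound 3 estimated as a 2.8-fold lower number from compound 1 to compound 3 (0.45 log units; beyond the scatter). Compound 3 is expected to give about 1500 nM, within a range from 400 nM to 5000 nM.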

Compound 3, solubility: 32000 nM
Estimate against measurement, compound 3: 21-fold (1.33 log units) below, and the stated range ends below it.
By their numbers in this assay, from the lowest: compounds 1 and 2 (each within the scatter of the next); then compound 3.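

In this assay, exchanging benzyl for naphthalen-1-yl on the shared core gives a 7.6-fold higher number from compound 1 to compound 3 (0.88 log units; beyond the scatter), so what sits at this position clearly changes the read-out. The entering group is the larger one by count, with 10 heavy atoms and two aromatic rings of carbon only against 7 heavy atoms and one such ring, yet the number goes up, which means that in this one pair more carbon at this place does not come with a less soluble compound. No supporting measurement is available to explain why the number rises.

From the compounds shown here alone, whether a phenyl group on the same aromatic carbon would read closer to compound 1 or to compound 3 remains open, so this single step cannot separate the effect of the second ring from that of losing the carbon that links the benzyl ring to the core. For the compounds shown here, compound 2 differs from compound 1 in more than one place and adds no step to this comparison, and how an amine or a carboxylic acid on that carbon would read in this assay is also unknown.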